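Same Change Twice, All Values at the Assay Limit

A few compounds are considered here, and "the series" means these few. Any claim that something is new, unique, unknown or untested is made for them only; others in the source may bear on it.

Compound 1, `CCOC(=O)c1c(-c2cccc(OC(C)C)c2)[nH]c2cc(OC)ccc2c1=O`, gives in an ADME assay on Raji cells (Homo sapiens) for cytotoxicity, read by luminescence, with a stated time of 72 h (on this read-out higher numbers stand for an effect only at larger amounts of compound and lower numbers for an effect already at smaller amounts), only a limit of the assay, > 21500 nM.
Compound 2, `CCOC(=O)c1c(-c2cccc(O)c2)[nH]c2cc(OC)ccc2c1=O`, gives in this assay only a limit of the assay, > 21500 nM.
Compound 3, `CCOC(=O)c1c(-c2cccc(-c3ccccc3)c2)[nH]c2cc(OC(C)C)ccc2c1=O`, gives in this assay only a limit of the assay, > 21500 nM.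

The change from compound 1 to compound 2 is hydrogen in place of isopropyl on an oxygen on an aromatic ring. The step it made in this assay is a step that the two limits leave unreadable from compound 1 to compound 2, so its size is not known. Compound 3 is built on a different core from compound 1; the difference between the two cores is not broken down here. Within the data shown here, compound 4, `CCOC(=O)c1c(-c2cccc(-c3ccccc3)c2)[nH]c2cc(O)ccc2c1=O`, has not been measured in this assay; it differs from compound 3 by hydrogen in place of isopropyl on an oxygen on an aromatic ring, which is the same change as the one from compound 1 to compound 2, made at the same kind of place. What the measured compounds offer as evidence is the limit of > 21500 nM in this assay, at which 3 of the 3 values shown sit, and none of the three gives a number.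

Because (the limit of > 21500 nM in this assay, at which 3 of the 3 values shown sit), compound 4 is expected to reach only a limit as well, with an estimated value of 30000 nM. The expected step is a step that the limit leaves unreadable from compound 3 to compound 4, placed beside the earlier step that the two limits leave unreadable from compound 1 to compound 2, which itself could not be read. Compound 4 is estimated to fall in the span from 12000 nM to 100000 nM, with a number rather than a limit regarded as unlikely.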

Compound 4, half-maximal effective concentration: > 21500 nM
Compound 4: a limit, no number (the forecaster's own chance of this, stated with the estimate: 85%); the middle value does not contradict the limit.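

In this assay compound 4 gives > 21500 nM as a limit of the assay and not a number. Among these compounds, no new step can be read: like the one from compound 1 to compound 2, the one from compound 3 to compound 4 joins two limits. The compounds shown leave open whether isopropoxy to hydroxy moves the value in this assay at all, and what number any of them would give, the only evidence being this: the limit of > 21500 nM in this assay, at which 4 of the 4 values shown sit.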